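Fluoro for methoxy on a nitro-bearing aryl ether

The source may report more compounds than this note shows. Statements on the series, on what has been measured and on what is new or still open speak of the compounds shown alone.

The study concerns three measured analogues and one still awaiting measurement. Compound 1 `COc1ccc(OC(C)(C)C2OCC(C/C=C\CCC(=O)O)C(c3cccnc3)O2)cc1` gives 41 nM in an assay for inhibition of Thromboxane-A synthase (Homo sapiens), using microsomes; on this read-out higher numbers stand for weaker inhibition and lower numbers for stronger inhibition. Compound 2 `CC(C)(Oc1ccc(F)cc1)C1OCC(C/C=C\CCC(=O)O)C(c2cccnc2)O1` gives 51 nM in this assay, and compound 3 `COc1ccc(OC(C)(C)C2OCC(C/C=C\CCC(=O)O)C(c3cccnc3)O2)c([N+](=O)[O-])c1` gives 37 nM in this assay. Compound 4 `CC(C)(Oc1ccc(F)cc1[N+](=O)[O-])C1OCC(C/C=C\CCC(=O)O)C(c2cccnc2)O1` has not yet been measured.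

The change from compound 1 to compound 2 is fluoro in place of methoxy on an aromatic carbon, and it made a 1.2-fold higher number from compound 1 to compound 2 (0.09 log units; within the scatter). The cores of compound 1 and compound 3 differ by nitro in place of hydrogen on an aromatic carbon, a step of a 1.1-fold lower number from compound 1 to compound 3 (0.04 log units; within the scatter). Between compound 2 and compound 3 the step is a 1.4-fold lower number from compound 2 to compound 3 (0.14 log units; within the scatter).

From compound 3 to compound 4 the change is fluoro in place of methoxy on an aromatic carbon. It is the same kind of change as that from compound 1 to compound 2, but here the place is also meta to a nitro group, which is not present around the place in compound 1 and compound 2. Compound 4 is expected to show a step of a 1.2-fold higher number from compound 3 to compound 4 (0.09 log units; within the scatter) in this assay; this rests on the size of a 1.2-fold higher number from compound 1 to compound 2 (0.09 log units; within the scatter). Compound 4 is therefore estimated at 45 nM, between 25 nM and 80 nM.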

Compound 4, half-maximal inhibitory concentration: 20 nM
Estimate against measurement, compound 4: 2.3-fold (0.35 log units) above; measured number outside the range, below it.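

In this assay, fluoro in place of methoxy on the nitro-bearing ring gives a 1.9-fold lower number from compound 3 to compound 4 (0.27 log units; within the scatter), and this does not differ from the same change without the nitro group by more than the scatter allows: the same change on two cores in this assay, a 1.2-fold higher number (0.09 log units; within the scatter) from compound 1 to compound 2 and a 1.9-fold lower number (0.27 log units; within the scatter) from compound 3 to compound 4, 2.3-fold (0.36 log units) apart, within the scatter of two such steps. Read the other way, nitro in place of hydrogen gives a 2.6-fold lower number from compound 2 to compound 4 (0.41 log units; beyond the scatter), a step beyond the scatter on its own, yet it cannot be told apart from the same change on the methoxy core: the same change on two cores in this assay, a 1.1-fold lower number (0.04 log units; within the scatter) from compound 1 to compound 3 and a 2.6-fold lower number (0.41 log units; beyond the scatter) from compound 2 to compound 4, 2.3-fold (0.36 log units) apart, within the scatter of two such steps. Going by these compounds alone, the two changes together give a 2.1-fold lower number from compound 1 to compound 4 (0.31 log units; beyond the scatter), so the series shows a modest gain in inhibition across the full replacement, but with only one pair of steps for each change it shows neither that a change carries over unaltered from one core to the other nor that the two changes depend on each other.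

The compounds shown leave open whether the fluoro step would hold with an amine or a nitrile in place of the nitro group. They also leave open whether chloro in place of fluoro would follow the same steps.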